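This account rests on a few compounds, and the source may have more. Where it says the series, first, only, none or still open, it means among the compounds named here.

Working notes on the series:

- compound 1 `CCCCCCCc1cc2cn(COCCO)c(O)nc-2n1`: 119000 nM
- compound 2 `CCCCCCCCCc1cc2cn(COCCO)c(=O)nc2o1`: >= 100000 nM
- compound 3 `O=c1nc2occc2cn1COCCO`: > 200000 nM

Among the measured compounds shown here, in a functional assay on HEL cells (Homo sapiens) (a higher number here means that more compound is tolerated, a lower number that less compound is tolerated), compound 1 gives 119000 nM, the only true number in the set. Compound 2 reports >= 100000 nM, which is a limit of the assay and not a number. Compound 3 reports > 200000 nM, which is also a limit.

The next compound is compound 4 `CCCCCCc1cc2cn(COCCO)c(O)nc-2n1`. Its difference from compound 1 is hydrogen in place of methyl on a saturated chain carbon, six bonds along the chain from an aromatic carbon, the same difference as butyl to propyl when cut further out.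

For the measured compounds named here, no measured step between compounds is available to calibrate this change. The expectation therefore rests on compound 1 at 119000 nM. In this assay no step beyond the scatter is expected, with any drift slightly towards more compound tolerated. The expected step of a 1.2-fold higher number from compound 1 to compound 4 (0.07 log units; within the scatter) is small. For compound 4 the estimated value is 140000 nM, with an expected range of 80000 nM to 240000 nM.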

Compound 4, half-maximal cytotoxic concentration: > 200000 nM
Compound 4 gave a limit, no number; the forecaster's own chance of this, stated with the estimate: 40%; at least 1.4-fold (0.15 log units) between middle value and limit.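

In this assay compound 4 reports > 200000 nM as a limit of the assay and not a number. Hydrogen in place of methyl on a saturated chain carbon, six bonds along the chain from an aromatic carbon, gives an at least 1.6-fold higher number from compound 1 to compound 4 (0.22 log units; that floor lies within the scatter) as the first readable step of the series, so this change at this position brings no fall in the number, though the true size of the step remains unread. With this change compound 4 joins the compounds read at the limit: the limit of > 200000 nM in this assay, at which 2 of the 4 values shown sit.

The compounds shown leave open how far the number of compound 4 lies past its limit, and so whether the step goes beyond the scatter. Also open, as far as these compounds go, is what a longer chain, or an amine in place of the chain, would do on the core of compound 1.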